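Phenoxy versus trifluoromethoxy on two quinolone cores: cytotoxicity notes

A few compounds are considered here, and "the series" means these few. Any claim that something is new, unique, unknown or untested is made for them only; others in the source may bear on it.

Compound 1 `CCOC(=O)c1c(-c2cccc(Oc3ccccc3)c2)[nH]c2cc(OC)ccc2c1=O` and compound 2 `CCOC(=O)c1c(-c2cccc(OC(F)(F)F)c2)[nH]c2cc(OC)ccc2c1=O` share one core; compound 3 `CCOC(=O)c1c(-c2cccc(Oc3ccccc3)c2)[nH]c2cc(F)cc(F)c2c1=O` and compound 4 `CCOC(=O)c1c(-c2cccc(OC(F)(F)F)c2)[nH]c2cc(F)cc(F)c2c1=O` share another, and the difference between the two cores is not broken down here. In an ADME assay on HEK293 cells (Homo sapiens) for cytotoxicity, read by luminescence, with a stated time of 72 h (a higher number here means that more compound is needed for the effect, a lower number that less compound is needed), compound 1 reaches only the limit > 22000 nM. Compound 2 likewise sits at the limit > 22000 nM in this assay. Compound 3 also gives only the limit > 22000 nM in this assay. The change from compound 1 to compound 2 is trifluoromethyl in place of phenyl on an oxygen on an aromatic ring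
and the same change recurs from compound 3 to compound 4 as trifluoromethyl in place of phenyl on an oxygen on an aromatic ring
The measured step that the two limits leave unreadable from compound 1 to compound 2 is not readable, since the limit of > 22000 nM in this assay, at which 3 of the 3 values shown sit, holds every value shown. For compound 4 the expected outcome in this assay is a step that the limit leaves unreadable from compound 3 to compound 4 that stays within the scatter, resting on compound 3 at > 22000 nM and the unreadable step that the two limits leave unreadable from compound 1 to compound 2. Compound 4 is therefore estimated at 30000 nM in this assay, between 15000 nM and 100000 nM, most likely reported as a limit again.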

Compound 4, half-maximal effective concentration: > 22000 nM
Compound 4: a limit, no number (the forecaster's own chance of this, stated with the estimate: 85%); the middle value does not contradict the limit.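

No step can be read from compound 3 to compound 4, nor from compound 1 to compound 2, because all four compounds give the same limit: the limit of > 22000 nM in this assay, at which 4 of the 4 values shown sit.

The compounds shown leave open whether phenoxy and trifluoromethoxy differ at all in this assay.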